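Piperidinyl Amide in Place of a Benzylic Amine Aryl

The compounds below may be only part of what the source reports. "The series", "measured", "known", "first", "only" and "open" are said of these compounds alone.

Of the compounds shown here, three sharing one core have been measured in an assay on CHO-K1 cells for displacement of a labelled ligand from prostaglandin E2 receptor EP1 subtype (Homo sapiens), read by scintillation counting, with a stated time of 30 min; a higher number here means a weaker inhibitor, a lower number a stronger inhibitor. Compound 1 `Cc1cc(C(=O)O)nn1Cc1cc(Cl)cn2cc(C(C)C)cc12` gives 126 nM. Compound 2 `Cc1cc(-c2nc3ccccc3[nH]2)nn1Cc1cc(Cl)cc2cc(C(C)C)oc12` gives 50.1 nM in this assay. Compound 3 `CNCc1ccc(NC(=O)c2cc(C)n(Cc3cc(Cl)cc4cc(C(C)C)oc34)n2)cc1` gives 63.1 nM in this assay; its number sits between those of compound 2 and compound 1, and both gaps fall within the usual scatter, so the three cannot be told apart. Compound 4 `Cc1cc(C(=O)NC2CCNCC2)nn1Cc1cc(Cl)cc2cc(C(C)C)oc12` has not yet been measured. It differs from compound 3 in one place: piperidin-4-yl in place of 4-((methylamino)methyl)phenyl on an amide-type nitrogen. For the measured compounds named here, no measured pair shows a change of this kind, so the expectation rests on little. Compound 4 is expected to come out somewhat weaker, with an estimated step of a 4.0-fold higher number from compound 3 to compound 4 (0.60 log units; beyond the scatter). Compound 4 is estimated at 250 nM, most likely between 60 nM and 1000 nM.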

Compound 4, half-maximal inhibitory concentration: 794 nM
The estimate for compound 4 lay 3.2-fold (0.50 log units) below the measured number, within the range that was stated.
By their numbers in this assay, from the lowest: compounds 2, 3 and 1 (each within the scatter of the next, the first and the last beyond it); then compound 4.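

In this assay the group on the amide nitrogen clearly matters: piperidin-4-yl in place of 4-((methylamino)methyl)phenyl gives a 13-fold higher number from compound 3 to compound 4 (1.10 log units; beyond the scatter). Likewise, (piperidin-4-yl)carbamoyl in place of 1H-benzimidazol-2-yl on an aromatic carbon gives a 16-fold higher number from compound 2 to compound 4 (1.20 log units; beyond the scatter), so not every group at this aromatic carbon is tolerated equally. Nothing available explains either step.

Still open, as far as these compounds go, is which part of 4-((methylamino)methyl)phenyl matters, the aromatic ring or the methylamino group. A plain phenyl or a cyclohexyl on the amide nitrogen would help to separate the two.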